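Neopentyl to isobutyl on an inactive compound

The compounds below may be only part of what the source reports. "The series", "measured", "known", "first", "only" and "open" are said of these compounds alone.

In a functional assay on HL-60 cells (Homo sapiens) for antiproliferative activity, read by MTT assay (on this read-out lower numbers stand for stronger inhibition and higher numbers for weaker inhibition), compound 1 (`O[C@@H]1[C@@H](OCc2ccccc2)[C@H](OCc2ccccc2)[C@@H](COCc2ccccc2)O[C@H]1Cc1ccccc1`) gives 8700 nM, and compound 2 (`O[C@@H]1[C@@H](OCc2ccccc2)[C@H](OCc2ccccc2)[C@@H](COCc2ccccc2)O[C@H]1c1ccccc1`) gives 26300 nM. Compound 3 (`CC(C)(C)C[C@@H]1O[C@H](COCc2ccccc2)[C@@H](OCc2ccccc2)[C@H](OCc2ccccc2)[C@H]1O`) has no single number on this scale, since compound 3 is reported as "not active" (no number reported). Compound 4 (`CC(C)C[C@@H]1O[C@H](COCc2ccccc2)[C@@H](OCc2ccccc2)[C@H](OCc2ccccc2)[C@H]1O`) differs from it by hydrogen in place of methyl on a saturated chain carbon bound to three saturated chain carbons, which turns neopentyl into isobutyl. Within the data shown here, only one measured step bears on this change, and only indirectly. It is a 3.0-fold higher number from compound 1 to compound 2 (0.48 log units; beyond the scatter), a modest step with phenyl in place of benzyl on a saturated ring carbon. With no number for compound 3, no step size can be calculated in this assay. The expected direction is towards a measurable value, but with activity staying weak and no better than that of the two measured compounds. Compound 4 may also prove not active. If it gives a number, compound 4 is expected at about 30000 nM, with an estimated range of 12000 nM to 80000 nM.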

Compound 4, half-maximal inhibitory concentration: 8500 nM
Beside the measured number, compound 4's estimate is 3.5-fold (0.55 log units) above it; the whole stated range lies above it.
By their numbers in this assay, from the lowest: compounds 4 and 1 (each within the scatter of the next); then compound 2.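

In this assay the change from neopentyl in compound 3, reported as not active, to isobutyl in compound 4 yields a measurable value, so this position can carry activity with a branched chain; the step itself cannot be read, as compound 3 has no number. Isobutyl in place of phenyl on a saturated ring carbon gives a 3.1-fold lower number from compound 2 to compound 4 (0.49 log units; beyond the scatter) and so sets compound 4 apart from the phenyl compound. Compound 4 nevertheless stays within the scatter of the benzyl compound, as shown by a 1.0-fold lower number from compound 1 to compound 4 (0.01 log units; within the scatter) and so the isobutyl and benzyl groups cannot be told apart here.

From the compounds shown here alone, whether an ethyl group, a longer chain such as n-pentyl or an amine on this carbon would hold the activity remains open. No measurement shown accounts for the difference between neopentyl and isobutyl.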